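Chloro for Methoxy: From Compound 2 to Compound 3

A few compounds are considered here, and "the series" means these few. Any claim that something is new, unique, unknown or untested is made for them only; others in the source may bear on it.

Compound 1 `Nc1ccccc1NC(=O)CCCNCC(=O)Nc1cc(Cl)ccc1Cl`: 78000 nM
Compound 2 `COc1ccc(NC(=O)CNc2ccc(C(=O)Nc3ccccc3N)cc2)cc1`: 38000 nM

Of the compounds shown here, two have so far been measured in a functional assay on HCT-116 cells (Homo sapiens) for inhibition, read by MTT assay, with a stated time of 2 days; a higher number here means a weaker inhibitor of growth, a lower number a stronger inhibitor of growth. Compound 1 gives 78000 nM, while compound 2 gives 38000 nM. Compound 2 therefore has the lower of the two numbers, and its gap to compound 1 lies beyond the scatter.

Compound 3 `Nc1ccccc1NC(=O)c1ccc(NCC(=O)Nc2ccc(Cl)cc2)cc1` differs from compound 2 in one place: chloro in place of methoxy on an aromatic carbon. Among the compounds with values here, no measured pair shows this change, so the step is expected to be small, in no direction beyond the scatter. Compound 3 is expected to give 32000 nM, between 11000 nM and 95000 nM. That estimate means an expected step of a 1.2-fold lower number from compound 2 to compound 3 (0.07 log units; within the scatter).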

Compound 3, concentration for total growth inhibition: 62500 nM
Compound 3: the middle estimate sits 2.0-fold (0.29 log units) below what was measured; the range from low to high includes it.
By their numbers in this assay, from the lowest: compounds 2, 3 and 1 (each within the scatter of the next, the first and the last beyond it).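

In this assay chloro in place of methoxy, on an aromatic carbon para to a large group, gives a 1.6-fold higher number from compound 2 to compound 3 (0.22 log units; within the scatter) and leaves the two groups indistinguishable at this position. Within the data shown here, this is the first reading of the change, and it rests on this single pair. No measurement at hand accounts for the step. Still open, going by these compounds, is whether an amine or a carboxylic acid at the same place would move the number beyond the scatter. On these data alone, whether the same change behaves alike on another core also remains open.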